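Trimming the Alkyl Chain of Compound 2

The compounds below may be only part of what the source reports. "The series", "measured", "known", "first", "only" and "open" are said of these compounds alone.

Within the data shown here, in a functional assay on A549 cells (Homo sapiens) for antiproliferative activity, read by MTT assay, with a stated time of 72 h (a lower number here means a stronger inhibitor, a higher number a weaker inhibitor), compound 2 `CCCCCCCCCCCCCCNC[C@@H]1OC[C@H](N)[C@H]1O` gives 20000 nM, the only exact number available so far. Compound 1 `CCCCCCCCNC[C@@H]1OC[C@H](N)[C@@H]1O` reads > 128000 nM, which is a limit of the assay and not a number. Compound 3 `CCCCCCCCCCNC[C@@H]1OC[C@H](N)[C@H]1O` differs from compound 2 by one change: hydrogen in place of butyl on a saturated chain carbon, ten or more bonds along the chain from an amine nitrogen. Among the measured compounds shown here, no measured step shows this change alone. For the measured compounds named here, the sole guide is the weak result of compound 1 at > 128000 nM, so a moderate weakening is expected, a 3.0-fold higher number from compound 2 to compound 3 (0.48 log units; beyond the scatter). Compound 3 is estimated at 60000 nM, with an expected range of 25000 nM to 128000 nM.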

Compound 3, half-maximal inhibitory concentration: > 128000 nM
Compound 3 ended at the assay's limit; the forecaster's own chance of this, stated with the estimate: 30%; at least 2.1-fold (0.32 log units) between middle value and limit.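

In this assay, placing hydrogen where butyl stood on a saturated chain carbon gives an at least 6.4-fold higher number from compound 2 to compound 3 (0.80 log units; beyond the scatter). Among these compounds, the outer end of the chain of compound 2 therefore counts in this read-out, which no earlier pair of compounds could show. As far as these compounds go, the step is only a minimum, and its full size stays unknown because compound 3 reads as a limit and not a number: the limit of > 128000 nM in this assay, at which 2 of the 3 values shown sit. From the compounds shown here alone, whether a longer chain, or an amine at the end of the chain, would lower the number remains open.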